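The source may report more compounds than this note shows. Statements on the series, on what has been measured and on what is new or still open speak of the compounds shown alone.

Compound 1 `COc1ccccc1-n1nc(C)c2c1NC(=O)[C@H](C)S[C@@H]2c1ccc(Oc2ccccc2)cc1`: 3300 nM
Compound 2 `CCCc1ccccc1-n1nc(C)c2c1NC(=O)[C@H](C)S[C@@H]2c1ccc(Oc2ccccc2)cc1`: 1100 nM
Compound 3 `Cc1ccc(-n2nc(C)c3c2NC(=O)[C@H](C)S[C@@H]3c2ccc(Oc3ccccc3)cc2)cc1`: 3400 nM

All three were tested in an assay on isolated protein for agonist activity at Bile acid receptor (Homo sapiens), read by AlphaScreen, with a stated time of 30 min; on this read-out higher numbers stand for an effect only at larger amounts of compound and lower numbers for an effect already at smaller amounts. For the measured compounds named here, compound 3 has the highest number of the three, though it sits within the scatter of compound 1; only the step of a 3.1-fold higher number from compound 2 to compound 3 (0.49 log units; beyond the scatter) stands beyond the scatter. The next compound, compound 4 `Cc1nn(-c2ccccc2C(C)C)c2c1[C@@H](c1ccc(Oc3ccccc3)cc1)S[C@@H](C)C(=O)N2`, differs from compound 3 in one place: 2-isopropylphenyl in place of 4-methylphenyl on an aromatic nitrogen. Going by the values given here, two measured steps bear on this. The step of a 3.1-fold higher number from compound 2 to compound 3 (0.49 log units; beyond the scatter) runs between a 2-propylphenyl and a 4-methylphenyl on the same nitrogen, and the step of a 3.0-fold lower number from compound 1 to compound 2 (0.48 log units; beyond the scatter) points the same way for propyl against methoxy. The 2-isopropylphenyl of compound 4 resembles the 2-propylphenyl of compound 2 more closely than the 4-methylphenyl of compound 3. Compound 4 is therefore expected to give a lower number, a 2.6-fold lower number from compound 3 to compound 4 (0.42 log units; beyond the scatter). Compound 4 is estimated at 1300 nM, between 500 nM and 3500 nM.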

Compound 4, half-maximal effective concentration: 1900 nM
Estimate against measurement, compound 4: 1.5-fold (0.16 log units) below; the measured number falls inside the stated range.
By their numbers in this assay, from the lowest: compounds 2, 4, 1 and 3 (each within the scatter of the next, the first and the last beyond it).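

With 2-isopropylphenyl on the aromatic nitrogen, compound 4 cannot be told apart from any of the three earlier compounds: each step stays within the scatter (a 1.8-fold lower number from compound 3 to compound 4 (0.25 log units; within the scatter)) (a 1.7-fold higher number from compound 2 to compound 4 (0.24 log units; within the scatter)) (a 1.7-fold lower number from compound 1 to compound 4 (0.24 log units; within the scatter)). Compound 4 therefore resolves neither side of the gap between compound 2 and compound 3, and isopropyl does not separate from propyl or methoxy on that aromatic carbon. No measurement shown accounts for this.

As far as these compounds go, what an amine or a longer chain such as butyl on this phenyl ring would give remains open. So does whether any group here can move the number beyond the scatter of compound 2.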